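A few compounds are considered here, and "the series" means these few. Any claim that something is new, unique, unknown or untested is made for them only; others in the source may bear on it.

Measured so far in a functional assay on NCI-H23 cells (Homo sapiens) for cytotoxicity, read by sulforhodamine B assay, with a stated time of 72 h; on this read-out higher numbers stand for weaker inhibition of growth and lower numbers for stronger inhibition of growth:

Compound 1 `O=C(Nc1ccc(C(F)(F)F)cc1)c1ccc2ccccc2n1` gives > 90000 nM, which is a limit of the assay and not a number.
Compound 2 `O=C(Nc1cc(C(F)(F)F)cc(C(F)(F)F)c1)C1CCc2ccccc2N1C(=O)c1ccc(Cl)cc1` gives 889 nM.
Compound 3 `O=C(Nc1ccccc1C(F)(F)F)C1CCc2ccccc2N1C(=O)c1ccc(Cl)cc1` gives 307 nM.

Compound 1 therefore stands apart from the other two: its result is only a limit (the limit of > 90000 nM in this assay, at which 1 of the 3 values shown sits), so no exact figure for it is known, only that growth inhibition was not reached within the tested range. Going by the values given here, compounds 2 and 3 are built on a different and larger core, and no step connects either of them to compound 1; their values show only that compounds of that other kind give measurable numbers in this assay.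

Compound 4 `COc1ccc(NC(=O)c2ccc3ccccc3n2)cc1` differs from compound 1 in one place: methoxy in place of trifluoromethyl on an aromatic carbon. Among the compounds with values here, no pair of measured compounds carries this change, so no measured step sets its size. The only anchor is the limit for compound 1. The expected change in this assay is a number no higher from compound 1 to compound 4 (the limit leaves the size open), that is none beyond the scatter. Compound 4 is estimated at 90000 nM, within a range from 20000 nM to 300000 nM, and most likely it will again be reported only as a limit.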

Compound 4, concentration for 50% growth inhibition: 7650 nM
The estimate for compound 4 lay 12-fold (1.07 log units) above the measured number; the measured number lies below the stated range.
By their numbers in this assay, from the lowest: compound 3; then compound 2; then compound 4. At a limit, above all of these: compound 1.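

In this assay, the substituent at this place on the ring proves to matter: methoxy in place of trifluoromethyl on an aromatic carbon, para to a large group, gives an at least 11-fold lower number from compound 1 to compound 4 (1.07 log units; beyond the scatter). Going by these compounds alone, compound 4 gives 7650 nM, so the core of compound 1 can carry a measurable number in this assay, which the earlier compounds could not show. The full size of the step stays unknown because compound 1 sits at a limit and has no exact number: the limit of > 90000 nM in this assay, at which 1 of the 4 values shown sits.

From the compounds shown here alone, whether this drop belongs to methoxy itself or would also come with another group at this place, such as an amine, a carboxylic acid or a longer chain like ethoxy, stays open. Also open, going by these compounds, is whether the same change would act alike on the larger core of compound 2 and compound 3.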